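The compounds below may be only part of what the source reports. "The series", "measured", "known", "first", "only" and "open" are said of these compounds alone.

Measured so far:
compound 1 `Nc1nc2ccnc(-c3ccccc3F)n2n1` at 218 mg/kg
compound 2 `Nc1nc2ccnc(-c3cccc(C(F)(F)F)c3)n2n1` at 166 mg/kg

In a functional assay on the whole organism with Mus musculus as the target (on this read-out higher numbers stand for an effect only at larger amounts of compound and lower numbers for an effect already at smaller amounts), compound 2 at 166 mg/kg stands level with compound 1 at 218 mg/kg within the scatter. Compound 3 `Nc1nc2ccnc(-c3cccc(OC(F)F)c3)n2n1` carries difluoromethoxy in place of trifluoromethyl on an aromatic carbon, a change counted as difluoromethoxy in place of trifluoromethyl on an aromatic carbon and not yet tested. Among the measured compounds shown here, no measured step covers this change. In this assay no shift beyond the scatter is expected. The estimated 1.0-fold higher number from compound 2 to compound 3 (0.01 log units; within the scatter) is expected to stay within that scatter. Compound 3 is expected at 170 mg/kg in a range from 85 mg/kg to 340 mg/kg on this read-out.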

Compound 3, dose for half-maximal effect: 138 mg/kg
Compound 3: middle estimate off by 1.2-fold (0.09 log units), on the high side; the range from low to high includes it.
By their numbers in this assay, from the lowest: compounds 3, 2 and 1 (each within the scatter of the next).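

In this assay, among the compounds shown here, the exchange of trifluoromethyl for difluoromethoxy, on an aromatic carbon meta to a large group, gives a 1.2-fold lower number from compound 2 to compound 3 (0.08 log units; within the scatter) as the first measured step at this position. The two groups therefore stand level here, even though difluoromethoxy adds an oxygen and a counted hydrogen-bond acceptor. No available data bear on a cause for this result.

Still open, from the compounds shown here alone, is whether an amine or a carboxylic acid at this position would move the number beyond the scatter. A longer chain such as propoxy poses the same question.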